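The source may hold more compounds than are shown below. What is called first, only, known or untested is meant among the compounds shown, and "the series" means these compounds.

Measured so far:
compound 1, `COc1ccc(/C=C/C(=O)Nc2cc3c(Nc4ccc(F)c(Cl)c4)ncnc3cc2OC)c(OC)c1`: 33300 nM
compound 2, `COc1ccc(OC)c(/C=C/C(=O)Nc2cc3c(Nc4ccc(F)c(Cl)c4)ncnc3cc2O[C@H]2CCOC2)c1`: 7300 nM
compound 3, `COc1cc(/C=C/C(=O)Nc2cc3c(Nc4ccc(F)c(Cl)c4)ncnc3cc2O[C@H]2CCOC2)cc(OC)c1`: 10800 nM

In a functional assay on A549 cells (Homo sapiens) for cytotoxicity, read by MTT assay, with a stated time of 72 h (on this read-out lower numbers stand for stronger inhibition and higher numbers for weaker inhibition), compound 2 gives 7300 nM, the lowest of the three numbers. Its nearest neighbour is compound 3, with a 1.5-fold higher number from compound 2 to compound 3 (0.17 log units; within the scatter); compound 1 lies beyond the scatter from it. Going by the values given here, compound 1 and compound 2 differ in two places, so their two values show only that the pair is separated, not what either change contributes.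

Compound 4, `O=C(/C=C/c1ccc(F)cc1Cl)Nc1cc2c(Nc3ccc(F)c(Cl)c3)ncnc2cc1O[C@H]1CCOC1`, has not yet been measured in this assay. Its change from compound 2 is 2-chloro-4-fluorophenyl in place of 2,5-dimethoxyphenyl on a double-bonded chain carbon bound to a double-bonded chain carbon.

Among the compounds with values here, only one measured step touches the same place: a 1.5-fold higher number from compound 2 to compound 3 (0.17 log units; within the scatter), where 3,5-dimethoxyphenyl in place of 2,5-dimethoxyphenyl left the number within the scatter. Within the data shown here, no measured pair replaces methoxy groups with halogens on this chain carbon, so there is no direct precedent for the change into compound 4. Among the measured compounds shown here, the single step at this place gives no reason to expect a shift beyond the scatter, but the different substitution type widens the uncertainty. The expected step for compound 4 is therefore a 1.0-fold higher number from compound 2 to compound 4 (0.01 log units; within the scatter), no direction beyond the scatter. Compound 4 is estimated at 7500 nM, between 2500 nM and 22000 nM.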

Compound 4, half-maximal inhibitory concentration: 5190 nM
Beside the measured number, compound 4's estimate is 1.4-fold (0.16 log units) above it, within the range that was stated.
By their numbers in this assay, from the lowest: compounds 4, 2 and 3 (each within the scatter of the next, the first and the last beyond it); then compound 1.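

In this assay, the 2-chloro-4-fluorophenyl group stands on the double-bonded chain carbon in place of 2,5-dimethoxyphenyl with a 1.4-fold lower number from compound 2 to compound 4 (0.15 log units; within the scatter), so a ring carrying halogens and no methoxy group is not separated from the dimethoxy ring at this position. Set against 3,5-dimethoxyphenyl, the same group gives a 2.1-fold lower number from compound 3 to compound 4 (0.32 log units; beyond the scatter), a modest step and the only one at this position beyond the scatter; since the two dimethoxy compounds are not themselves separated, the series shows at most a shallow dependence on the ring substituents tried so far. No measurement is available to explain any of these steps.

Going by these compounds, the substituents on this ring are still limited to methoxy, chloro and fluoro, so it remains open how an amine, a carboxylic acid or a longer chain at this position would read. Compound 1 differs from the other compounds in more than one place, so the separate contribution of its methoxy group on the shared core cannot be read from these values.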